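The compounds below may be only part of what the source reports. "The series", "measured", "known", "first", "only" and "open" are said of these compounds alone.

Of the compounds shown here, three sharing one core have been read in a functional assay on HGC cells (Homo sapiens) for cytotoxicity, read by MTT assay, with a stated time of 48 h; a lower number here means a stronger inhibitor, a higher number a weaker inhibitor. Compound 1 `CCn1c(/C=C2/C(=O)Nc3ccc(C)cc32)nc2ccccc21` gives > 50000 nM, which is a limit of the assay and not a number. Compound 2 `CCn1c(/C=C2/C(=O)Nc3ccc(Br)cc32)nc2ccccc21` gives > 50000 nM, again a limit and not a number. Going by the values given here, the one measured step between them, a step that the two limits leave unreadable from compound 1 to compound 2, bromo in place of methyl on an aromatic carbon, therefore has no readable size. Among the compounds with values here, compound 3 `CC(C)n1c(/C=C2/C(=O)Nc3ccc(Cl)cc32)nc2ccccc21` gives 32800 nM, the only true number.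

Compound 4 `CCn1c(/C=C2/C(=O)Nc3ccc(Cl)cc32)nc2ccccc21` is reached from compound 3 by a small change: hydrogen in place of methyl on a saturated chain carbon bound to an aromatic nitrogen and a saturated chain carbon, so that isopropyl becomes ethyl. Within the data shown here, no measured step covers this change. Among the measured compounds shown here, the only guide is the limit of > 50000 nM in this assay, at which 2 of the 3 values shown sit, and both compounds at that limit carry the ethyl group that compound 4 would gain. Compound 4 may thus well return a limit too. The expected change is no larger than the scatter, leaning toward weaker inhibition, and reads a 1.4-fold higher number from compound 3 to compound 4 (0.14 log units; within the scatter). For compound 4 the estimated value is 45000 nM, with an expected range from 22000 nM to 90000 nM.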

Compound 4, half-maximal inhibitory concentration: > 50000 nM
Compound 4 gave a limit, no number; the forecaster's own chance of this, stated with the estimate: 55%; middle value at least 1.1-fold (0.04 log units) from the limit.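

In this assay, the change from isopropyl to ethyl, on a saturated chain carbon bound to an aromatic nitrogen and a saturated chain carbon, gives the series its first step with one readable side: an at least 1.5-fold higher number from compound 3 to compound 4 (0.18 log units; that floor lies within the scatter). Compound 4 returned a limit and not a number, so this figure is a floor and not a size, and with that floor inside the scatter the step alone does not establish that isopropyl differs from ethyl here. The steps among compound 1, compound 2 and compound 4, which differ only in methyl, bromo or chloro on an aromatic carbon, cannot be read, and compound 3 remains the only one with a true number: the limit of > 50000 nM in this assay, at which 3 of the 4 values shown sit.

On these data alone, it remains open whether a longer chain, or a chain carrying an amine, at this place would give a clearly lower number than compound 3 at 32800 nM. Also open, as far as these compounds go, is how bromo or methyl on the aromatic carbon would read alongside isopropyl, a pairing that could make those aromatic steps readable.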